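The source may report more compounds than this note shows. Statements on the series, on what has been measured and on what is new or still open speak of the compounds shown alone.

Measured compounds, antiproliferative activity in a functional assay on HepG2 cells (Homo sapiens) for antiproliferative activity, read by MTT assay, with a stated time of 24 h; a higher number here means a weaker inhibitor, a lower number a stronger inhibitor:
Compound 1, `COc1ccc(C2=NN(c3ccc(-c4ccccc4)nn3)C(c3ccc(F)cc3)C2)cc1`, gives 9160 nM.
Compound 2, `COc1ccc(C2=NN(c3ccc(-c4ccccc4)nn3)C(c3ccc(C(F)(F)F)cc3)C2)cc1`, gives > 100000 nM; this is a limit of the assay, not a number.
Compound 3, `COc1ccc(C2=NN(c3ccc(-c4ccccc4)nn3)C(c3ccc(OC)cc3)C2)cc1`, gives > 100000 nM; this too is a limit of the assay, not a number.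

Compound 3 therefore stands at the weak end of what this assay reports, sharing the limit noted as the limit of > 100000 nM in this assay, at which 2 of the 3 values shown sit, with compound 2. The step from compound 1 to compound 2 was an at least 10-fold higher number from compound 1 to compound 2 (1.03 log units; beyond the scatter), and the step from compound 1 to compound 3 was an at least 10-fold higher number from compound 1 to compound 3 (1.03 log units; beyond the scatter); the step between compound 2 and compound 3 is a step that the two limits leave unreadable from compound 2 to compound 3.

Compound 4, `COc1ccc(C2=NN(c3ccc(-c4ccccc4)nn3)C(c3cc(OC)c(OC)c(OC)c3)C2)cc1`, differs from compound 3 in one place: 3,4,5-trimethoxyphenyl in place of 4-methoxyphenyl on a saturated ring carbon. Both measured steps show that changing the group on this saturated ring carbon moves the value strongly, but neither involves a change of this kind, so no direction can be read from them, and with compound 3 itself at a limit the size of the step from compound 3 to compound 4 cannot be anchored. It is expected that this assay will again report a limit or a weak value for compound 4, with a number no higher from compound 3 to compound 4 (the limit leaves the size open) as the estimated step. The estimated value for compound 4 in this assay is 100000 nM, within a range of 15000 nM to 300000 nM.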

Compound 4, half-maximal inhibitory concentration: > 100000 nM
Compound 4: only a limit was reported; the forecaster's own chance of this, stated with the estimate: 65%; the middle value sits exactly at the limit.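

In this assay, the larger 3,4,5-trimethoxyphenyl group on the saturated ring carbon leaves compound 4 at > 100000 nM, which is a limit and not a number. Placing this group where compound 1 carries 4-fluorophenyl gives an at least 10-fold higher number from compound 1 to compound 4 (1.03 log units; beyond the scatter), so compound 1 remains the only compound shown with a readable number, now against three other groups at this position. The steps among compound 2, compound 3 and compound 4 cannot be read, and the series gathers at a single value: the limit of > 100000 nM in this assay, at which 3 of the 4 values shown sit.

Open, from the compounds shown here alone, is whether any group other than 4-fluorophenyl at this position gives a readable number, for instance a phenyl ring carrying chloro, hydroxy or an amine. Also open, going by these compounds, is how far compound 2, compound 3 and compound 4 lie beyond the limit, so no order among them can be given.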